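Lipophilicity notes: swapping the aryl group on the benzylic arm

A few compounds are considered here, and "the series" means these few. Any claim that something is new, unique, unknown or untested is made for them only; others in the source may bear on it.

Compound 1 `CCNC(=O)c1cc(C(=O)NC)c(=O)n(Cc2ccccc2)c1` and compound 2 `CNC(=O)c1cc(C(=O)NC2CC2)cn(Cc2cccc3[nH]ccc23)c1=O` share a core. In a physicochemical assay for lipophilicity, at pH 7.4 (on this read-out lower numbers stand for lower lipophilicity and higher numbers for higher lipophilicity), compound 1 gives 3, and compound 2 gives 2.9; compound 2 stands lowest of the two, with compound 1 within the scatter of it. Compound 3 `CNC(=O)c1cc(C(=O)NC2CC2)cn(Cc2ccccc2F)c1=O` follows from compound 2 by one change: 2-fluorophenyl in place of 1H-indol-4-yl on a saturated chain carbon bound to an aromatic nitrogen. Among the compounds with values here, no measured step shows this change, so the expected step of a number 0.20 log units higher from compound 2 to compound 3 (within the scatter) is small and upward, not clearly beyond the scatter. In this assay compound 3 is expected at 3.1, in the range 2.7 to 3.5.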

Compound 3, distribution coefficient: 3
For compound 3 the middle estimate is 0.10 log units above the measured one; measured number inside the range.
By their numbers in this assay, from the lowest: compounds 2, 1 and 3 (each within the scatter of the next).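

In this assay, 2-fluorophenyl in place of 1H-indol-4-yl on a saturated chain carbon bound to an aromatic nitrogen gives a number 0.10 log units higher from compound 2 to compound 3 (within the scatter). This single step at the position removes the five-membered aromatic ring and the hydrogen-bond donor of 1H-indol-4-yl, yet the two numbers stay within the scatter. No supporting measurement bears on this result.

This one pair of aryl groups supports no pattern for the position. Going by these compounds, whether an amine or a carboxylic acid at this place would give a step beyond the scatter remains open.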